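The source may hold more compounds than are shown below. What is called first, only, known or untested is meant among the compounds shown, and "the series" means these compounds.

Measured compounds:
compound 1, `NC(=O)c1c(NC(=O)c2ccccc2Cl)sc2c1CCN(C(=S)Nc1ccc(C(F)(F)F)cc1)C2`: 7090 nM
compound 2, `NC(=O)c1c(NC(=O)c2ccc(C(F)(F)F)cc2)sc2c1CCN(C(=S)Nc1ccccc1Cl)C2`: 16400 nM

Both numbers come from a functional assay on MKN-74 cells (Homo sapiens) for antiproliferative activity, with a stated time of 24 h; on this read-out higher numbers stand for weaker inhibition and lower numbers for stronger inhibition. In this assay compound 1 gives 7090 nM and compound 2 gives 16400 nM; of the two, compound 2 has the higher number, and its gap to compound 1 lies beyond the usual scatter, so compound 2 is the weaker inhibitor of this pair. The two share the same core and differ in which aryl group sits on the amide carbonyl and which on the amide-type nitrogen whose other neighbour is the thiocarbonyl carbon.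

Compound 3, `NC(=O)c1c(NC(=O)c2ccc(C(F)(F)F)cc2)sc2c1CCN(C(=S)Nc1ccc(C(F)(F)F)cc1)C2`, has not yet been measured. It keeps the amide side of compound 2 and changes only the other side: 4-(trifluoromethyl)phenyl in place of 2-chlorophenyl on an amide-type nitrogen. Among the measured compounds shown here, no measured pair differs in this one place alone, so the size of the step cannot be read off directly. Compound 1, which carries the same 4-(trifluoromethyl)phenyl on that nitrogen, gives 7090 nM, a lower number than compound 2, and on that basis a modest move toward a lower number is expected, though it may also stay within the scatter. This change is expected to give a step of a 1.9-fold lower number from compound 2 to compound 3 (0.29 log units; within the scatter). Compound 3 is therefore estimated at 8500 nM, with a range from 3000 nM to 22000 nM.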

Compound 3, half-maximal inhibitory concentration: 12300 nM
Estimate against measurement, compound 3: 1.4-fold (0.16 log units) below; the range from low to high includes it.
By their numbers in this assay, from the lowest: compounds 1, 3 and 2 (each within the scatter of the next, the first and the last beyond it).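

In this assay, 4-(trifluoromethyl)phenyl in place of 2-chlorophenyl on the amide-type nitrogen whose other neighbour is the thiocarbonyl carbon gives a 1.3-fold lower number from compound 2 to compound 3 (0.12 log units; within the scatter), so at this position the two aryl groups cannot be told apart. The same exchange on the carbonyl carbon gives a 1.7-fold higher number from compound 1 to compound 3 (0.24 log units; within the scatter), so neither exchange, taken alone, produces a change that can be separated from ordinary variation between repeated measurements. Nothing available here offers an explanation for these results, either for this position or for the other.

On these data alone, what remains open is how far the read-out can move at these two positions when the aryl group is replaced by something quite different, such as a longer alkyl chain, or when the ring carries an amine or a carboxylic acid. As far as these compounds go, it also remains open whether the small steps seen with these two aryl groups would hold on other cell types or with a different exposure time.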